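The source may report more compounds than this note shows. Statements on the series, on what has been measured and on what is new or still open speak of the compounds shown alone.

Compound 1 `Cc1cn([C@@H]2O[C@@H]3COC(=O)[C@]3(OS(C)(=O)=O)[C@H]2O)c(=O)[nH]c1=O`: >= 250000 nM (a limit)
Compound 2 `COC(=O)CNC1=CS(=O)(=O)O[C@@]12[C@@H](CO[Si](C)(C)C(C)(C)C)O[C@@H](n1cc(C)c(=O)n(C)c1=O)[C@@H]2O[Si](C)(C)C(C)(C)C`: 105000 nM

For the measured compounds named here, in a functional assay on MT4 cells (Homo sapiens) (a higher number here means that more compound is tolerated, a lower number that less compound is tolerated), compound 2 gives 105000 nM, the only actual number available. Compound 1 gives >= 250000 nM, which is a limit of the assay and not a number.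

Compound 3 `COC(=O)CC(=O)NC1=CS(=O)(=O)O[C@@]12[C@@H](CO[Si](C)(C)C(C)(C)C)O[C@@H](n1cc(C)c(=O)n(C)c1=O)[C@@H]2O[Si](C)(C)C(C)(C)C` is compound 2 altered in one place, with ((methoxycarbonyl)methyl)carbonyl in place of (methoxycarbonyl)methyl on an amine nitrogen. Going by the values given here, no measured pair shows what a change of this kind does in this assay, so the expectation is anchored on compound 2 at 105000 nM. No step beyond the usual scatter is expected, and neither direction is favoured. The estimated step is a 1.1-fold lower number from compound 2 to compound 3 (0.02 log units; within the scatter). For compound 3, the expected value is 100000 nM, with an estimated range of 35000 nM to 250000 nM.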

Compound 3, half-maximal cytotoxic concentration: 11900 nM
Compound 3: the middle estimate sits 8.4-fold (0.92 log units) above what was measured; measured number below the stated range.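

In this assay the swap of (methoxycarbonyl)methyl for ((methoxycarbonyl)methyl)carbonyl on this amine nitrogen gives an 8.8-fold lower number from compound 2 to compound 3 (0.95 log units; beyond the scatter). For the compounds shown here, this is the first readable step in the set, and it shows that the group on this nitrogen is not a silent spot: with the rest of the molecule unchanged, a change here alone moves the number beyond the usual scatter, and downward, so less compound is tolerated. Nothing shown here bears on why this step arises.

The compounds shown leave open whether the carbonyl itself carries the step, which a simple acetyl group on the same nitrogen could help separate, or whether the methyl ester plays a part, which a free carboxylic acid in its place could test. A single pair also cannot say whether the same change would act alike on a different core.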